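The compounds below may be only part of what the source reports. "The series", "measured", "known", "first", "only" and "open" are said of these compounds alone.

Measured in a functional assay on HeLa cells (Homo sapiens) for cytotoxicity, read by MTT assay, with a stated time of 48 h; a lower number here means a stronger inhibitor, a higher number a weaker inhibitor:

Compound 1 `COc1cc([C@H]2C[C@@]2(CO)C(=O)Nc2ccccc2)cc(OC)c1OC`: > 100000 nM, a limit of the assay
Compound 2 `COc1cc([C@H]2C[C@]2(CO)C(=O)Nc2ccccc2Cl)cc(OC)c1OC`: 45500 nM

Among the compounds with values here, compound 2 holds the only actual number in this small set, since the other reading is a limit, as the limit of > 100000 nM in this assay, at which 1 of the 2 values shown sits, shows. Compound 3 `COc1cc([C@H]2C[C@]2(CO)C(=O)Nc2ccccc2)cc(OC)c1OC` differs from compound 2 by a single change, hydrogen in place of chloro on an aromatic carbon, ortho to a large group. Within the data shown here, no measured pair shows what this swap does here, so any forecast remains uncertain. A modest weakening in this assay is expected, of about the size of the usual scatter or somewhat more, and the reading could also end at the limit of the assay. The expected change is a 1.5-fold higher number from compound 2 to compound 3 (0.19 log units; within the scatter). Compound 3 is estimated at 70000 nM, with an expected range of 25000 nM to 160000 nM.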

Compound 3, half-maximal inhibitory concentration: > 100000 nM
Compound 3 was reported as a limit; the forecaster's own chance of this, stated with the estimate: 40%; at least 1.4-fold (0.15 log units) between middle value and limit.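

Going from 2-chlorophenyl to phenyl in this assay gives an at least 2.1-fold higher number from compound 2 to compound 3 (0.34 log units; beyond the scatter), the first measured pair for this change on an aromatic carbon ortho to a large group. Compound 3 is recorded only as a limit of the assay, so the step has a lower bound but no full size: the limit of > 100000 nM in this assay, at which 2 of the 3 values shown sit. The step between compound 1 and compound 3 cannot be read, so these compounds show nothing about the configuration at the saturated ring carbon: the fact that compounds 1 and 3 differ only in the configuration as drawn.

From the compounds shown here alone, whether a fluoro, methyl or methoxy group on the same aromatic carbon would also give a measurable reading remains open. Also open, going by these compounds, is whether the chloro group would give a measurable reading in the configuration of compound 1.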